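The source may hold more compounds than are shown below. What is called first, only, known or untested is meant among the compounds shown, and "the series" means these compounds.

Measured compounds:
Compound 1, `Nc1ccccc1NC(=O)c1ccc(CSC(=S)N2CCN(C3CCCCC3)CC2)cc1`, in a functional assay on MGC-803 cells (Homo sapiens) for antiproliferative activity, read by CCK-8 assay, with a stated time of 72 h, tested at 8 uM (on this read-out higher numbers stand for a stronger effect at the one concentration tested and lower numbers for a weaker effect), gives 75.3%.
Compound 2, `Nc1ccccc1NC(=O)c1ccc(CSC(=S)N2CCc3ccc([N+](=O)[O-])cc32)cc1`, in this assay gives 39.6%.
Compound 3, `CN(Cc1ccncc1)C(=S)SCc1ccc(C(=O)Nc2ccccc2N)cc1`, in this assay gives 83.2%.

Among these three numbers compound 1 holds the second highest place. Its nearest neighbour is compound 3, whose value lies within the usual scatter of compound 1, so the two cannot be told apart on this read-out. Compound 2 is the furthest away: its value sits well below that of compound 1, a gap beyond the scatter.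

Compound 4, `Nc1ccccc1NC(=O)c1ccc(CSC(=S)N2CCN(c3ccc(F)cc3)CC2)cc1`, has not yet been measured in this assay. It differs from compound 1 in one place: 4-fluorophenyl in place of cyclohexyl on an amine nitrogen in a ring. Within the data shown here, no pair of measured compounds differing in a single place is available, so the size of this step is not known from a direct comparison. Since compound 1 and compound 3 carry quite different groups on the thiocarbamate nitrogen and still give values within the scatter of each other, the step of a number 5.3 percentage points lower from compound 1 to compound 4 (within the scatter) is expected to be small, most likely none beyond the scatter. Compound 4 is therefore estimated at 70%, with a range from 50% to 88%.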

Compound 4, a percentage reported as inhibition, at one concentration (the size of the read-out at that concentration, not a potency): 48.7%
Compound 4: the middle estimate sits 21.3 percentage points above what was measured; measured number outside the range, below it.
By their numbers in this assay, from the lowest: compounds 2 and 4 (each within the scatter of the next); then compounds 1 and 3 (each within the scatter of the next).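

In this assay, among these compounds, placing 4-fluorophenyl in place of cyclohexyl on the amine nitrogen in the ring gives a number 26.6 percentage points lower from compound 1 to compound 4 (beyond the scatter) as the first step at a single place in this set. It shows that this position does not accept every group alike: the two groups are both six-membered carbon rings, with no hydrogen-bond donors or acceptors and no net charge, yet the read-out separates them. Nothing at hand accounts for the drop.

As far as these compounds go, whether the step belongs to the aromatic ring or to the fluorine remains open, and a plain phenyl on the same nitrogen would separate the two. How a methyl or a benzyl group on this nitrogen would compare also stays unanswered.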